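From benzoylmethyl to 3-nitrophenyl: a cell toxicity check

The compounds below may be only part of what the source reports. "The series", "measured", "known", "first", "only" and "open" are said of these compounds alone.

Compound 1 `O=C(COC(=O)c1ccc([N+](=O)[O-])o1)NC1CCc2ccccc21` gives > 100000 nM here
Compound 2 `CC(C)(C)N(CCC(=O)c1ccccc1)C(=O)COC(=O)c1ccc([N+](=O)[O-])o1` gives "not active" (no number reported) here
Compound 3 `CC(C)(C)N(Cc1cccc([N+](=O)[O-])c1)C(=O)COC(=O)c1ccc([N+](=O)[O-])o1` is not yet measured

These compounds are compared in an ADME assay on HEK-293T cells (Homo sapiens) for cytotoxicity, read by MTT assay, with a stated time of 3 days (on this read-out lower numbers stand for higher toxicity in this test and higher numbers for lower toxicity in this test), as the test of how harmful each one is to cells. Compound 1 gives > 100000 nM in this test, which is a limit of the assay and not a number. Compound 2 stands without any figure, reported as "not active" (no number reported) in the same test, so it can be placed on no numerical scale.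

The structural change to follow is 3-nitrophenyl in place of benzoylmethyl on a saturated chain carbon bound to an amide-type nitrogen. The rest of the molecule stays the same. Among the compounds with values here, no measured pair in this small set shows what a single change does, so the expectation rests on very little. Compound 3 is expected to behave like compound 2 in this assay because compound 2 reads "not active" (no number reported) there. Compound 3 may well be reported only as a limit, as compound 1 is.

The estimate for compound 3 is 100000 nM (expected range 30000 nM to 200000 nM).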

Compound 3, half-maximal cytotoxic concentration: 78000 nM
Beside the measured number, compound 3's estimate is 1.3-fold (0.11 log units) above it, and the stated range covers the measured number.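

No step can be read from compound 2 to compound 3: in this assay compound 2 is reported as "not active" (no number reported) while compound 3 gives 78000 nM and only the second of these is a number. Compound 1 offers only a limit of the assay, not a number: the limit of > 100000 nM in this assay, at which 1 of the 3 values shown sits. Left open is whether 3-nitrophenyl in place of benzoylmethyl changes toxicity to these cells at all, and by how much.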